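A few compounds are considered here, and "the series" means these few. Any claim that something is new, unique, unknown or untested is made for them only; others in the source may bear on it.

Of the compounds shown here, three that share one core have been measured in a functional assay on PC-6 cells (Homo sapiens) for antiproliferative activity; on this read-out lower numbers stand for stronger inhibition and higher numbers for weaker inhibition. Compound 1, `CC(C)c1cc2c(N/N=C\c3ccccn3)ncnc2s1`, gives 0.003 ug/mL in this assay. Compound 2, `CC(C)(C)c1cc2c(N/N=C\c3ccccn3)ncnc2s1`, gives 0.009 ug/mL, and compound 3, `CC(C)(C)c1cc2c(N/N=C\c3cccnc3)ncnc2s1`, gives 1.45 ug/mL. Among these three numbers compound 2 stands second highest: the step of a 3.0-fold higher number from compound 1 to compound 2 (0.48 log units; beyond the scatter) is modest, whereas the step of a 160-fold higher number from compound 2 to compound 3 (2.21 log units; beyond the scatter) is large.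

The next compound, compound 4, is `CNCc1cccc(/C=N\Nc2ncnc3sc(C(C)(C)C)cc23)n1`. It differs from compound 2 by (methylamino)methyl in place of hydrogen on an aromatic carbon, on an aromatic carbon of a six-membered aromatic ring with 1 nitrogen, next to the ring nitrogen and meta to a large group.

Neither measured step is the same kind of change. The step of a 3.0-fold higher number from compound 1 to compound 2 (0.48 log units; beyond the scatter) shows that a small addition on the saturated side of the molecule costs only a little, while the step of a 160-fold higher number from compound 2 to compound 3 (2.21 log units; beyond the scatter) shows that this assay responds strongly to where the ring nitrogen sits in the ring attached to the hydrazone. Among the compounds with values here, a new group placed next to that ring nitrogen could therefore matter, but the data give no direct precedent. For compound 4 a modest to sizeable weakening is expected, with the step of a 3.3-fold higher number from compound 2 to compound 4 (0.52 log units; beyond the scatter), giving an estimated 0.03 ug/mL within a range from 0.005 ug/mL to 0.3 ug/mL.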

Compound 4, half-maximal inhibitory concentration: 0.189 ug/mL
Estimate against measurement, compound 4: 6.3-fold (0.80 log units) below, within the range that was stated.
By their numbers in this assay, from the lowest: compound 1; then compound 2; then compound 4; then compound 3.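

In this assay the step of a 21-fold higher number from compound 2 to compound 4 (1.32 log units; beyond the scatter) comes from placing (methylamino)methyl on the aromatic carbon next to the ring nitrogen, and it is large. Within the data shown here, until now, the only large change in the six-membered aromatic ring with 1 nitrogen was the shift of the ring nitrogen in the step of a 160-fold higher number from compound 2 to compound 3 (2.21 log units; beyond the scatter) and so this result adds something new: the read-out also responds strongly to a group added to that ring while its nitrogen stays where it is in compound 2. The added group lowers the potency without removing it, since compound 4 still gives 0.189 ug/mL in this assay and a measurable inhibition remains with this group in place.

Nothing in the data shown gives a reason for this step. Going by these compounds, it remains open whether the loss follows the amine itself or any group on this carbon, and a plain methyl, a hydroxymethyl or a longer chain ending in an amine at the same place would help to tell these cases apart.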